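From 4-methylbenzyl to 3-methoxybenzyl: an estimate

The source may hold more compounds than are shown below. What is called first, only, known or untested is meant among the compounds shown, and "the series" means these compounds.

Measured so far:
Compound 1 `C=C1CC[C@@H]2[C@](C)(CO)[C@H](O)CC[C@@]2(C)[C@@H]1CCC1C(=O)OC[C@H]1O`: > 30000 nM
Compound 2 `C=C1CC[C@@H]2[C@](C)(CO)[C@H](O)CC[C@@]2(C)[C@@H]1C/C=C1\C=COC1=O`: 2770 nM
Compound 3 `C=C1CC[C@@H]2[C@](C)(CNCc3ccc(C)cc3)[C@H](O)CC[C@@]2(C)[C@@H]1/C=C/C1=CCOC1=O`: 740 nM

In a functional assay on BMMC cells (Mus musculus, strain C57BL/6) for inhibition, with stated times of 5 days and 48 h (a higher number here means a weaker inhibitor, a lower number a stronger inhibitor), compound 1 reports only a limit of the assay, (the limit of > 30000 nM in this assay, at which 1 of the 3 values shown sits). For the measured compounds named here, compound 2 gives a real number, and the step of an at least 10-fold lower number from compound 1 to compound 2 (1.03 log units; beyond the scatter) is the only measured step in this set. Compound 3 gives the lowest of the two numbers, and its gap to compound 2 lies beyond the scatter.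

Compound 4 `C=C1CC[C@@H]2[C@](C)(CNCc3cccc(OC)c3)[C@H](O)CC[C@@]2(C)[C@@H]1/C=C/C1=CCOC1=O` differs from compound 3 in one place: 3-methoxyphenyl in place of 4-methylphenyl on a saturated chain carbon bound to an amine nitrogen. Going by the values given here, no measured step touches that part of the molecule; the step of an at least 10-fold lower number from compound 1 to compound 2 (1.03 log units; beyond the scatter) sits on a different part of the shared core and gives no guidance here. No step beyond the scatter is therefore expected.

Compound 4 is expected near 740 nM, within 300 nM to 1800 nM. The expected step is no change at the digits printed from compound 3 to compound 4 (within the scatter).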

Compound 4, half-maximal inhibitory concentration: 780 nM
Compound 4: middle estimate off by 1.1-fold (0.02 log units), on the low side, within the range that was stated.
By their numbers in this assay, from the lowest: compounds 3 and 4 (each within the scatter of the next); then compound 2. At a limit, above all of these: compound 1.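

In this assay, placing 3-methoxyphenyl instead of 4-methylphenyl on the saturated chain carbon bound to the amine nitrogen gives a 1.1-fold higher number from compound 3 to compound 4 (0.02 log units; within the scatter). For the compounds shown here, this is the first measured step at this place in the molecule, and it shows that these two groups cannot be told apart in this assay. Nothing measured here accounts for that result.

Only these two substituted phenyl groups have been compared at this place. From the compounds shown here alone, what a carboxylic acid on the phenyl ring, or a plain phenyl ring, would do remains open.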